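The compounds below may be only part of what the source reports. "The series", "measured", "known", "first", "only" and "open" are said of these compounds alone.

Measured so far in a functional assay on RPMI-8226 cells (Homo sapiens) for inhibition, read by sulforhodamine B assay, with a stated time of 48 h, tested at 10 uM; on this read-out lower numbers stand for less inhibition and higher numbers for more inhibition at the one concentration tested (going by the name of the read-out):
compound 1, `Brc1cn2ccnc2c(-c2ccc3ncn(C4CCCCC4)c3c2)n1`, gives 14.9%
compound 2, `c1ccc(-c2cn3ccnc3c(-c3ccc4ncn(C5CCCCC5)c4c3)n2)cc1`, gives 85.7%

Compound 2 stands highest of the two numbers in this assay; the nearest is compound 1, and the step of a number 70.8 percentage points higher from compound 1 to compound 2 (beyond the scatter) separates them. Compound 3, `Clc1ccc(-c2cn3ccnc3c(-c3ccc4ncn(C5CCCCC5)c4c3)n2)cc1`, is not yet measured. It differs from compound 2 in one place: chloro in place of hydrogen on an aromatic carbon. Among the compounds with values here, the single measured step bears on this only loosely: it shows that phenyl in place of bromo moves this assay a long way, but it says nothing about a chloro added to that phenyl. Within the data shown here, no measured compound carries a substituted phenyl, so the size of the coming step has no direct precedent. A small change of this kind is expected to leave the number near that of compound 2. The step of a number 1.7 percentage points lower from compound 2 to compound 3 (within the scatter) is expected to lie within the scatter. Compound 3 is therefore estimated to give 84%, with a range from 68% to 96%.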

Compound 3, a percentage reported as inhibition, at one concentration (the size of the read-out at that concentration, not a potency): 19%
Beside the measured number, compound 3's estimate is 65 percentage points above it; the measured number lies below the stated range.
By their numbers in this assay, from the lowest: compounds 1 and 3 (each within the scatter of the next); then compound 2.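

In this assay, chloro in place of hydrogen on the phenyl ring, para to a large group, gives a number 66.7 percentage points lower from compound 2 to compound 3 (beyond the scatter), so this place on the phenyl ring responds strongly to the addition of one heavy atom. With 4-chlorophenyl in place of bromo, the change is a number 4.1 percentage points higher from compound 1 to compound 3 (within the scatter), which shows that a phenyl ring at this point of the shared core does not by itself bring high inhibition. Nothing available explains why the added chloro has so large an effect.

As far as these compounds go, it remains open whether this loss is specific to chloro or would also follow from another group at the same place, such as fluoro, methoxy or an amine. The compounds shown also do not tell how a chloro elsewhere on the phenyl ring would behave.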